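Fluorosulfonyl Replaces the Carbamate on the Aromatic Oxygen

The source may report more compounds than this note shows. Statements on the series, on what has been measured and on what is new or still open speak of the compounds shown alone.

Measured compounds:
Compound 1, `CC1(C)C=C(n2ccccc2=O)c2cc(OCC(=O)c3ccccc3)ccc2O1`, gives 5.05 in a functional assay (aorta) with Rattus norvegicus as the target; on this read-out higher numbers stand for higher potency (the scale is a negative logarithm) and lower numbers for lower potency.
Compound 2, `CC1(C)C=C(n2ccccc2=O)c2cc(OC(=O)Nc3ccccc3)ccc2O1`, gives 5.3 in this assay.
Compound 3, `CC1(C)C=C(n2ccccc2=O)c2cc(OC(=O)Nc3ccc(F)cc3)ccc2O1`, gives 5.3 in this assay.

Compound 3 stands level with compound 2 at the digits shown, and the two together hold the highest numbers of the three in this assay. Its distance from compound 1 is a number 0.25 log units higher from compound 1 to compound 3 (within the scatter), and from compound 2 it is no change at the digits printed from compound 2 to compound 3 (within the scatter), so nothing among the three separates from the others beyond the scatter.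

Compound 4, `CC1(C)C=C(n2ccccc2=O)c2cc(OS(=O)(=O)F)ccc2O1`, has not yet been measured in this assay. Compared with compound 3 the change is fluorosulfonyl in place of (4-fluorophenyl)carbamoyl on an oxygen on an aromatic ring.

Going by the values given here, three measured steps touch this place. Two of them exchange the whole group on the oxygen on the aromatic ring: a number 0.25 log units higher from compound 1 to compound 2 (within the scatter) and a number 0.25 log units higher from compound 1 to compound 3 (within the scatter). The third, no change at the digits printed from compound 2 to compound 3 (within the scatter), alters only the outer part of that group. Among the compounds with values here, all three stay within the scatter, so the numbers so far show no step at this position that can be told from noise. Within the data shown here, the change to compound 4 is, however, larger than any of those measured, removing the ring entirely, and no measured pair covers a group this small at that oxygen. The expected step for compound 4 is therefore a number 0.20 log units lower from compound 3 to compound 4 (within the scatter), a small shift with a wide band of doubt. Compound 4 is estimated at 5.1, with a range from 4.5 to 5.7.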

Compound 4, logarithm of the reciprocal of the active concentration, log(1/C): 7.95
For compound 4 the middle estimate is 2.85 log units below the measured one; measured number above the stated range.
By their numbers in this assay, from the lowest: compounds 1, 2 and 3 (each within the scatter of the next); then compound 4.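

In this assay the group on the oxygen on an aromatic ring proves able to move the read-out a long way, with a number 2.65 log units higher from compound 3 to compound 4 (beyond the scatter), a number 2.65 log units higher from compound 2 to compound 4 (beyond the scatter) and a number 2.90 log units higher from compound 1 to compound 4 (beyond the scatter). Going by these compounds alone, the flat picture from the earlier steps therefore holds only among benzoylmethyl, phenylcarbamoyl and (4-fluorophenyl)carbamoyl, each of which carries a six-membered aromatic ring of carbon only, whereas fluorosulfonyl has no ring and stands well clear of all three. Nothing at hand bears on why this exchange has so large an effect.

The exchange changes several things at once, removing the ring and the carbamoyl nitrogen and bringing in sulfur, so the compounds shown cannot tell which of these goes with the higher number. A methylsulfonyl group, an acetyl group or a plain hydrogen on that oxygen would each separate part of this, showing whether the sulfonyl unit, the fluorine on sulfur or simply the loss of the ring goes with the rise.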